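Carbamoyl in Place of Hydroxy: Expectation for Compound 4

The source may report more compounds than this note shows. Statements on the series, on what has been measured and on what is new or still open speak of the compounds shown alone.

compound 1 `CC(=O)NCCN(C)c1cccc(OCCCCN)c1`: 12900 nM
compound 2 `CC(=O)NCCN(C)c1cccc(OCCCCCCNC(=O)Oc2cccc(-c3ccccc3)c2)c1`: 33.1 nM
compound 3 `CC(=O)NCCN(C)c1cccc(OCCCCCCNC(=O)Oc2cccc(-c3cccc(O)c3)c2)c1`: 26.9 nM

In an assay on cells for displacement of a labelled ligand from melatonin receptor type 1B (Homo sapiens), using the Cheng-Prusoff equation, with a stated time of 90 min (a lower number here means a stronger inhibitor, a higher number a weaker inhibitor), compound 3 and compound 2 stand within the usual scatter of each other, while compound 1 lies far above both. Compound 4 `CC(=O)NCCN(C)c1cccc(OCCCCCCNC(=O)Oc2cccc(-c3cccc(C(N)=O)c3)c2)c1` differs from compound 3 by carbamoyl in place of hydroxy on an aromatic carbon. Within the data shown here, the only measured step at this position, a 1.2-fold lower number from compound 2 to compound 3 (0.09 log units; within the scatter), shows hydroxy and hydrogen giving numbers within the scatter of each other. Among the measured compounds shown here, no measured step covers carbamoyl at this place, so the new group is untested. For compound 4 the expected step is therefore a 1.4-fold higher number from compound 3 to compound 4 (0.15 log units; within the scatter), not beyond the scatter. Compound 4 is accordingly estimated at 38 nM, with a range from 12 nM to 120 nM in this assay.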

Compound 4, inhibition constant: 15.5 nM
Estimate against measurement, compound 4: 2.5-fold (0.39 log units) above; low and high end bracket the measured number.
By their numbers in this assay, from the lowest: compounds 4, 3 and 2 (each within the scatter of the next, the first and the last beyond it); then compound 1.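

Carbamoyl gives the first step at this position that lies beyond the scatter, though a modest one, when it replaces hydrogen (a 2.1-fold lower number from compound 2 to compound 4 (0.33 log units; beyond the scatter)). Against hydroxy it stays within the scatter (a 1.7-fold lower number from compound 3 to compound 4 (0.24 log units; within the scatter)), so in this assay these two groups cannot be ordered, and the change from 3-hydroxyphenyl to 3-carbamoylphenyl costs nothing despite the larger group. Nothing measured here accounts for the difference from hydrogen.

The compounds shown leave open how an amine or a carboxylic acid would fare at this place. They also leave open whether carbamoyl at another place on this ring would give a similar number.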